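The source may hold more compounds than are shown below. What is called first, only, known or untested is meant among the compounds shown, and "the series" means these compounds.

Three compounds share a core in which a sulfonyl group joins an aromatic ring to a ring nitrogen. Compound 1 `CNCc1cc(-c2cccnc2F)n(S(=O)(=O)c2cccnc2)c1` carries pyridin-3-yl on that sulfonyl sulfur, and in a functional assay on the whole organism (strain Jcl:Sprague-Dawley) for inhibition, with Rattus norvegicus as the target, with stated times of 3 min and 3 h, at a dose of 1 mg/kg by the intravenous route (on this read-out higher numbers stand for more inhibition at the one dose given (going by the name of the read-out) and lower numbers for less inhibition), compound 1 gives 96%. Compound 2 `CNCc1cc(-c2cccnc2F)n(S(=O)(=O)c2ccsc2)c1` carries thiophen-3-yl there instead, and compound 2 gives 98%; the step of a number 2 percentage points higher from compound 1 to compound 2 (within the scatter). Compound 3 `CNCc1cn(S(=O)(=O)c2cccs2)c(-c2cccnc2F)c1F` carries thiophen-2-yl on the sulfonyl sulfur, and compound 3 gives 98%, level with compound 2 at the digits shown, so that the two together stand at the top of the three numbers, while compound 1 sits a gap below that lies within the scatter.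

Compound 4 `CNCc1cn(S(=O)(=O)c2ccccn2)c(-c2cccnc2F)c1F` differs from compound 3 in one place: pyridin-2-yl in place of thiophen-2-yl on a sulfonyl sulfur. Among the compounds with values here, the only measured step that speaks to this kind of exchange is the swap between a pyridinyl and a thiophenyl ring on the same sulfonyl sulfur, a number 2 percentage points higher from compound 1 to compound 2 (within the scatter), which stayed inside the scatter. Since every measured number here lies high and level with the others within the scatter, a step from compound 3 to compound 4 of no more than the scatter is expected in this assay, in no particular direction. Compound 4 is therefore expected to give 95%, between 85% and 100%. The expected step of a number 3 percentage points lower from compound 3 to compound 4 (within the scatter) is thus estimated to fall within the scatter.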

Compound 4, a percentage reported as inhibition, in the whole organism at one dose (the size of the read-out at that dose, not a potency): 95%
The estimate for compound 4 equals the measured number at the digits printed, and the stated range covers the measured number.
By their numbers in this assay, from the lowest: compounds 4, 1, 2 and 3 (each within the scatter of the next).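

In this assay the exchange of thiophen-2-yl for pyridin-2-yl on the sulfonyl sulfur gives a number 3 percentage points lower from compound 3 to compound 4 (within the scatter) and so does not separate the two rings. The earlier pair offered only the 3-yl forms of these rings, with a number 2 percentage points higher from compound 1 to compound 2 (within the scatter) on the core of compound 1; the new pair shows that the 2-yl forms, on the core of compound 3, also stay within the scatter, so a six-membered ring with one nitrogen and a five-membered ring with one sulfur read alike in both pairs. Nothing given here explains why the number holds across this exchange.

Going by these compounds, the read-out in this assay gives the size of the inhibition at a single dose and is not a potency, so with all four numbers lying high and level, any difference between these rings that would appear at a lower dose remains unknown. Also open, on these data alone, is whether the number would hold with a plain phenyl ring on the sulfonyl sulfur, or with a ring there bearing a carboxylic acid or an amine.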